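Cinnamamide-benzophenone series: dropping a methoxy from the styryl ring

The source may hold more compounds than are shown below. What is called first, only, known or untested is meant among the compounds shown, and "the series" means these compounds.

Measured so far: compound 1 `COc1ccc(/C=C/C(=O)Nc2cc(C(=O)c3cc(OC)c(OC)c(OC)c3)ccc2OC)cc1` gives 11800 nM in a functional assay on ME-180 cells (Homo sapiens) for cytotoxicity, read by MTT assay, with a stated time of 72 h; on this read-out higher numbers stand for weaker inhibition and lower numbers for stronger inhibition; compound 2 `COc1cc(C(=O)c2cc(OC)c(OC)c(OC)c2)cc(NC(=O)/C=C/c2cc(OC)c(OC)c(OC)c2)c1OC` gives 3900 nM; compound 3 `COc1ccc(/C=C/C(=O)Nc2cc(C(=O)c3cc(OC)c(OC)c(OC)c3)cc(OC)c2OC)cc1OC` gives 6700 nM.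

Compound 3 stands second highest of the three numbers; the nearest is compound 2 and the furthest compound 1, and both gaps are within the scatter, so no order among the three is claimed.

Compound 4 `COc1ccc(/C=C/C(=O)Nc2cc(C(=O)c3cc(OC)c(OC)c(OC)c3)cc(OC)c2OC)cc1` has not been measured. It differs from compound 3 in one place: hydrogen in place of methoxy on an aromatic carbon.

Among the measured compounds shown here, one measured step bears on this kind of change. From compound 2 to compound 3 a methoxy was likewise replaced by hydrogen, and the result was a 1.7-fold higher number from compound 2 to compound 3 (0.24 log units; within the scatter). The styryl ring of compound 4 is also that of compound 1, and in this assay compound 1 shows 11800 nM. Taken together, the step of a 1.3-fold higher number from compound 3 to compound 4 (0.13 log units; within the scatter) is expected to be small, towards a higher number if anything, but not beyond the scatter. Compound 4 is therefore estimated at 9000 nM, with a range from 4500 nM to 18000 nM.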

Compound 4, half-maximal inhibitory concentration: 12500 nM
Beside the measured number, compound 4's estimate is 1.4-fold (0.14 log units) below it, within the range that was stated.
By their numbers in this assay, from the lowest: compounds 2, 3, 1 and 4 (each within the scatter of the next, the first and the last beyond it).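

Taking 3,4-dimethoxyphenyl to 4-methoxyphenyl gives a 1.9-fold higher number from compound 3 to compound 4 (0.27 log units; within the scatter) in this assay and so leaves this single methoxy loss inside the scatter on a second compound pair. Only the wider change from 3,4,5-trimethoxyphenyl to 4-methoxyphenyl clears the scatter, with a 3.2-fold higher number from compound 2 to compound 4 (0.51 log units; beyond the scatter) as a modest step, so two methoxy losses that cannot be told apart one at a time become readable together across compound 2, compound 3 and compound 4. With 4-methoxyphenyl held, the methoxy on the core gives a 1.1-fold higher number from compound 1 to compound 4 (0.03 log units; within the scatter) and no readable change, and the same hydrogen-for-methoxy change agrees on two cores: the same change on two cores in this assay, a 1.7-fold higher number (0.24 log units; within the scatter) from compound 2 to compound 3 and a 1.1-fold lower number (0.03 log units; within the scatter) from compound 4 to compound 1, 1.8-fold (0.26 log units) apart, within the scatter of two such steps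

The compounds shown leave open whether a hydroxyl or an amine on this aromatic carbon would read differently from hydrogen or methoxy. They also leave open what happens when the 4-methoxyphenyl group loses its remaining methoxy.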